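Swapping bromo for iodo on a shared hydrazide core

A few compounds are considered here, and "the series" means these few. Any claim that something is new, unique, unknown or untested is made for them only; others in the source may bear on it.

Compound 2 `C/C(=N\NC(=O)c1ccncc1)C(=O)Nc1ccc(Br)cc1` belongs to a small set built on one shared core. In a functional assay on HepG2 cells (Homo sapiens) for cytotoxicity, read by MTT assay, with a stated time of 72 h (a higher number here means a weaker inhibitor, a lower number a stronger inhibitor), compound 2 gives > 50000 nM, which is a limit of the assay rather than a number. Its neighbour compound 1 `C/C(=N\NC(=O)c1ccncc1)C(=O)Nc1ccc(C(F)(F)F)cc1` carries a trifluoromethyl group where compound 2 carries bromo. In this assay compound 1 gives > 50000 nM, again a limit of the assay. The step that the two limits leave unreadable from compound 1 to compound 2 therefore cannot be read, since both values sit at the limit of > 50000 nM in this assay, at which 2 of the 2 values shown sit. Compound 3 `C/C(=N\NC(=O)c1ccncc1)C(=O)Nc1ccc(I)cc1` is not yet measured; it differs from compound 2 by iodo in place of bromo on an aromatic carbon. Among the measured compounds shown here, no measured step shows how this change acts, and the one step known is unreadable, so no shift beyond the scatter can be foreseen. Compound 3 is expected to give about 50000 nM, between 20000 nM and 200000 nM, most probably once more as a limit. The expected step of a number no higher from compound 2 to compound 3 (the limit leaves the size open) is thus essentially none.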

Compound 3, half-maximal inhibitory concentration: > 50000 nM
Compound 3 was reported as a limit; the forecaster's own chance of this, stated with the estimate: 85%; the middle value lies on the limit itself.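

In this assay compound 3 gives > 50000 nM, a limit of the assay, so the steps to it from compound 1 and compound 2 cannot be read: the limit of > 50000 nM in this assay, at which 3 of the 3 values shown sit.

The compounds shown leave open whether trifluoromethyl, bromo and iodo differ in their effect at all, and how strong each compound really is.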